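The source may hold more compounds than are shown below. What is called first, only, known or untested is meant among the compounds shown, and "the series" means these compounds.

Measured in an ADME assay on microsomes from liver (Homo sapiens) for metabolic stability, using NADPH, with a stated time of 10 min; a lower number here means that less of the compound is left, a higher number that more of the compound is left:
- compound 1 `NCCCCN(C[C@H]1Cc2ncccc2CN1)[C@H]1CCCc2cccnc21`: 100%
- compound 2 `NCCCCN(C[C@@H]1Cc2ncccc2CN1)[C@H]1CCCc2cccnc21`: 98%
- compound 3 `NCCCCN(C[C@H]1Cc2nccnc2CN1)[C@H]1CCCc2cccnc21`: 84%

Compound 2 lies within the scatter of compound 1 and beyond the scatter above compound 3. Compound 4 `CN(C[C@@H]1Cc2ncccc2CN1)[C@H]1CCCc2cccnc21` is reached from compound 2 by one change: hydrogen in place of 3-aminopropyl on a saturated chain carbon bound to an amine nitrogen. Among the compounds with values here, the only measured step, a number 2 percentage points lower from compound 1 to compound 2 (within the scatter), is a change of configuration alone (the fact that compounds 1 and 2 differ only in the configuration as drawn), so it says little about this change. Within the data shown here, no measured step covers the loss of this chain. With compound 2 at 98%, little room remains upward, so a modest fall is expected, though perhaps none beyond the scatter. The expected size is an estimated a number 10 percentage points lower from compound 2 to compound 4 (within the scatter). For compound 4 the estimated value is 88%, with an expected range of 68% to 100%.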

Compound 4, percent of the compound remaining: 100%
The estimate for compound 4 lay 12 percentage points below the measured number; low and high end bracket the measured number.
By their numbers in this assay, from the lowest: compound 3; then compounds 2, 1 and 4 (each within the scatter of the next).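

In this assay, hydrogen in place of 3-aminopropyl on a saturated chain carbon bound to an amine nitrogen gives a number 2 percentage points higher from compound 2 to compound 4 (within the scatter). The 4-aminobutyl chain on compound 2 can therefore be cut back to methyl with no change beyond the scatter, so this position tolerates the loss of the chain's terminal amine and nearly all of its length in this assay. Nothing at hand accounts for this step.

Still open, as far as these compounds go, is how a carboxylic acid or a longer chain without an amine would read at this position. From the compounds shown here alone, the same cut on the core of compound 3 also remains open.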